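A Second Chloro on the Shared Core: What to Expect

The source may report more compounds than this note shows. Statements on the series, on what has been measured and on what is new or still open speak of the compounds shown alone.

Compound 1 `ClCc1ccc(Cn2cnc3c(Cl)ncnc32)cc1` gives 22900 nM in a functional assay on TK-10 cells (Homo sapiens) for cytotoxicity, read by sulforhodamine B assay, with a stated time of 48 h; a higher number here means that more compound is tolerated, a lower number that less compound is tolerated.
Compound 2 `ClCc1ccccc1Cn1cnc2c(Cl)nc(Cl)nc21` gives 5620 nM in this assay.
Compound 3 `ClCc1ccccc1Cn1cnc2c(Cl)ncnc21` gives 95500 nM in this assay.

Among these three numbers, compound 1 stands second highest: compound 2 lies closest, with a lower number, and compound 3 lies furthest, with a higher one, and both gaps exceed the scatter. Compound 4 `ClCc1ccc(Cn2cnc3c(Cl)nc(Cl)nc32)cc1` has not yet been measured. It differs from compound 1 in one place: chloro in place of hydrogen on an aromatic carbon.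

Going by the values given here, one measured step bears directly on this change, in the reverse direction: a 17-fold higher number from compound 2 to compound 3 (1.23 log units; beyond the scatter). There, taking the chloro away from the same position of the core raised the number markedly. Adding it back in compound 4 is therefore expected to lower the number by a step of a similar size, a 13-fold lower number from compound 1 to compound 4 (1.10 log units; beyond the scatter), well beyond the scatter. Among the compounds with values here, only one such pair is known, so the range is kept wide. Compound 4 is expected to give about 1800 nM, between 500 nM and 7000 nM.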

Compound 4, concentration lethal to 50% of the cells: 44700 nM
Estimate against measurement, compound 4: 25-fold (1.40 log units) below, outside the stated range (above it).
By their numbers in this assay, from the lowest: compound 2; then compounds 1 and 4 (each within the scatter of the next); then compound 3.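

In this assay, putting a chloro on the aromatic carbon between two ring nitrogen atoms gives a 2.0-fold higher number from compound 1 to compound 4 (0.29 log units; within the scatter), so on this core compounds 1 and 4 cannot be told apart. This position therefore has no single effect that can be carried from one compound to another, and a large step on one core says little about the same change on a closely related core. What the chloro does here depends on the rest of the molecule, and the two steps clearly differ: the same change on two cores in this assay, a 17-fold higher number (1.23 log units; beyond the scatter) from compound 2 to compound 3 and a 2.0-fold lower number (0.29 log units; within the scatter) from compound 4 to compound 1, 33-fold (1.52 log units) apart, beyond the scatter of two such steps

Each core offers only one such pair, so the compounds shown cannot say which feature of the rest of the molecule sets this difference. Going by these compounds, it also remains open whether an amine or a methoxy group on this same carbon would follow either core's pattern.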